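This account rests on a few compounds, and the source may have more. Where it says the series, first, only, none or still open, it means among the compounds named here.

Measured compounds:
- Compound 1 `COc1ccc(N(C)c2nc(C)nc3ccccc23)cc1C(=O)OCCC[Se]C#N`: 854 nM
- Compound 2 `C[Se]c1ccc(N(C)c2nc(C)nc3ccccc23)cc1C`: 9 nM

Of the compounds shown here, two sharing the same core have been tested in a functional assay on LoVo cells (Homo sapiens) for inhibition, read by MTT assay, with a stated time of 48 h; a lower number here means a stronger inhibitor, a higher number a weaker inhibitor. Compound 1 gives 854 nM, the higher of the two numbers, and compound 2 gives 9 nM, a lower number whose gap from compound 1 lies beyond the usual scatter. For the measured compounds named here, since compound 1 and compound 2 differ in more than one place, these two values alone describe the pair, and no single structural step can be drawn between them.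

Compound 3 `COc1ccc(N(C)c2nc(C)nc3ccccc23)cc1OCCCCC[Se]C#N` has not yet been measured. It differs from compound 1 in one place:

a group of 9 heavy atoms (6 carbon, 1 nitrogen, 1 oxygen, 1 selenium; no ring) in place of a group of 9 heavy atoms (5 carbon, 1 nitrogen, 2 oxygen, 1 selenium; no ring), on an aromatic carbon

Going by the values given here, no measured pair in this set shows the effect of such a change, so there is little to anchor an expectation. The chain that enters and the chain that leaves are of the same size, and the rest of the molecule is unchanged. The step from compound 1 to compound 3 in this assay is therefore expected to be small, a 1.3-fold lower number from compound 1 to compound 3 (0.12 log units; within the scatter), with no confident direction. Compound 3 is estimated at 650 nM, within a range of 150 nM to 2800 nM.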

Compound 3, half-maximal inhibitory concentration: 5210 nM
Beside the measured number, compound 3's estimate is 8.0-fold (0.90 log units) below it, outside the stated range (above it).
By their numbers in this assay, from the lowest: compound 2; then compound 1; then compound 3.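

At this position, on an aromatic carbon ortho to a methoxy group, two chains of equal size prove not to be interchangeable in this assay: putting the group of 9 heavy atoms with 6 carbon and 1 oxygen in place of the group of 9 heavy atoms with 5 carbon and 2 oxygen gives a 6.1-fold higher number from compound 1 to compound 3 (0.79 log units; beyond the scatter). The chain that leaves has 1 double bond outside aromatic rings and 3 hydrogen-bond acceptors, whereas the chain that enters has no such double bond and 2 hydrogen-bond acceptors, so heavy-atom count alone does not set the number at this place. Nothing measured on these compounds accounts for the size of the step, and no reason for it can be given from the data at hand.

The compounds shown leave open which part of the exchange carries the step, since the ester carbonyl and the oxygen attachment to the ring change together in this one move. An amide in the chain, or a shorter alkyl chain on the same ring oxygen, would be the kind of group that could begin to separate these features.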